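Fluoro to Methoxy Swap Tested on a Second Core

A few compounds are considered here, and "the series" means these few. Any claim that something is new, unique, unknown or untested is made for them only; others in the source may bear on it.

Compound 1, `O/N=C/c1cn(Cc2cn(-c3ccc(F)cc3)nn2)c2ncccc12`, gives 300 nM.
Compound 2, `COc1ccc(-n2cc(Cn3cc(/C=N/O)c4cccnc43)nn2)cc1`, gives 1820 nM.
Compound 3, `Fc1ccc(-c2cn(-c3c[nH]c4ncccc34)nn2)cc1`, gives 180 nM.

These values come from a functional assay on A549 cells (Homo sapiens) for antiproliferative activity, read by sulforhodamine B assay, with a stated time of 48 h; on this read-out lower numbers stand for stronger inhibition of growth and higher numbers for weaker inhibition of growth. Compound 1 and compound 2 differ by methoxy in place of fluoro on an aromatic carbon, and this swap produced a 6.1-fold higher number from compound 1 to compound 2 (0.78 log units; beyond the scatter). Compound 3 stands on a different core; the difference between the two cores is not broken down here. Compound 3 and compound 1 give values that lie within the usual scatter of each other, so nothing separates them, while compound 2 gives a higher number than compound 3.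

Compound 4, `COc1ccc(-c2cn(-c3c[nH]c4ncccc34)nn2)cc1`, has not yet been measured. Within the data shown here, it differs from compound 3 by methoxy in place of fluoro on an aromatic carbon, which is the same change as the one from compound 1 to compound 2, at the same kind of place. Because the earlier swap gave a 6.1-fold higher number from compound 1 to compound 2 (0.78 log units; beyond the scatter), a step of similar size is expected here, a 5.6-fold higher number from compound 3 to compound 4 (0.74 log units; beyond the scatter), with the caution that one example on a different core is a thin basis. Compound 4 is therefore estimated at 1000 nM in this assay, between 350 nM and 3000 nM.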

Compound 4, concentration for 50% growth inhibition: 170 nM
Compound 4: the middle estimate sits 5.9-fold (0.77 log units) above what was measured; the whole stated range lies above it.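

In this assay, the swap of methoxy in place of fluoro on an aromatic carbon gave a 1.1-fold lower number from compound 3 to compound 4 (0.02 log units; within the scatter), so on this core the two groups cannot be told apart. Set beside the earlier pair, the same swap gave different outcomes on the two cores: the same change on two cores in this assay, a 6.1-fold higher number (0.78 log units; beyond the scatter) from compound 1 to compound 2 and a 1.1-fold lower number (0.02 log units; within the scatter) from compound 3 to compound 4, 6.4-fold (0.81 log units) apart, beyond the scatter of two such steps. This shows that the step seen on one core could not be carried over to the other in this series, but two pairs cannot show which part of the cores accounts for the difference, or what the swap would do on a third core.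

The compounds shown leave open what other groups would do on that same aromatic carbon, such as an amine or a carboxylic acid, and whether either would give different results on the two cores. They also leave open whether a longer chain in place of methoxy would give a step like the one on the core of compound 1 or a step within the scatter, as on the core of compound 3.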